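Trifluoromethoxy in place of fluoro on the fused ring

The compounds below may be only part of what the source reports. "The series", "measured", "known", "first", "only" and "open" are said of these compounds alone.

Compound 1 `Cc1ccc2nc(C(=O)Nc3c(F)cc(-c4cccc(F)c4)cc3F)c(C)c(O)c2c1` gives 37.3% in a functional assay on Hep 3B2 cells (Homo sapiens) for antiproliferative activity, read by MTT assay, with a stated time of 24 h, tested at 33.33 ug/mL; on this read-out lower numbers stand for a weaker effect and higher numbers for a stronger effect at the one concentration tested. Compound 2 `Cc1c(C(=O)Nc2c(F)cc(-c3cccc(F)c3)cc2F)nc2ccc(F)cc2c1O` gives 41.2% in this assay; the step of a number 3.9 percentage points higher from compound 1 to compound 2 (within the scatter) is the only one measured so far. Among the measured compounds shown here, compound 2 therefore stands nowhere apart: its only neighbour, compound 1, lies within the scatter of it, and no order between the two can be read.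

Compound 3 `Cc1c(C(=O)Nc2c(F)cc(-c3cccc(F)c3)cc2F)nc2ccc(OC(F)(F)F)cc2c1O` differs from compound 2 by trifluoromethoxy in place of fluoro on an aromatic carbon. For the measured compounds named here, the one measured step bears on it only in that it sits at the same place on the same ring, and that step a number 3.9 percentage points higher from compound 1 to compound 2 (within the scatter) stayed within the scatter. Going by the values given here, no measured step exchanges fluoro for trifluoromethoxy, so in this assay no step beyond the scatter is expected in either direction, and the estimate for compound 3 is 40%, between 25% and 55%, which amounts to an expected step of a number 1.2 percentage points lower from compound 2 to compound 3 (within the scatter).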

Compound 3, a percentage reported as inhibition, at one concentration (the size of the read-out at that concentration, not a potency): 41.3%
Beside the measured number, compound 3's estimate is 1.3 percentage points below it; the measured number falls inside the stated range.
By their numbers in this assay, from the lowest: compounds 1, 2 and 3 (each within the scatter of the next).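

Exchanging fluoro for trifluoromethoxy at this aromatic carbon of the fused system gives a number 0.1 percentage points higher from compound 2 to compound 3 (within the scatter) in this assay, and exchanging methyl for trifluoromethoxy gives a number 4 percentage points higher from compound 1 to compound 3 (within the scatter) on the same read-out. The position therefore takes a group of five heavy atoms, with one hydrogen-bond acceptor, in place of a single fluorine with no step beyond the scatter. Methyl, fluoro and trifluoromethoxy at this carbon cannot be ordered in this series.

On these data alone, whether an amine, a carboxylic acid or a longer chain at this carbon would move the number beyond the scatter remains open. So does whether these three compounds would separate at other concentrations or as full potencies. No available evidence bears on this result.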